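The compounds below may be only part of what the source reports. "The series", "measured", "known", "first", "only" and "open" are said of these compounds alone.

Measured compounds:
compound 1, `CC(=O)c1ccc(C(=O)N[C@@H](C)Cn2ccc(-c3ccc(C#N)c(Cl)c3)n2)cc1`, 3600 nM
compound 2, `C[C@@H](Cn1ccc(-c2ccc(C#N)c(Cl)c2)n1)NC(=O)c1ccccc1F`, 1810 nM
compound 3, `C[C@@H](Cn1ccc(-c2ccc(C#N)c(Cl)c2)n1)Nc1ccnc2ccccc12`, 4810 nM

All three share one core and were tested in a functional assay on LNCaP cells (Homo sapiens) for antiproliferative activity, read by CCK-8 assay, with a stated time of 6 days; on this read-out higher numbers stand for weaker inhibition and lower numbers for stronger inhibition. Compound 2 has the lowest of the three numbers: compound 1 sits within the scatter of it, while compound 3 lies beyond the scatter above it. Going by the values given here, the only single-point step among them, a 2.0-fold lower number from compound 1 to compound 2 (0.30 log units; within the scatter), is within the scatter, so the measured comparisons give little leverage on how the group attached to the amine nitrogen matters.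

Compound 4, `C[C@@H](Cn1ccc(-c2ccc(C#N)c(Cl)c2)n1)Nc1ncnc2nc[nH]c12`, differs from compound 2 by a group of 9 heavy atoms (5 carbon, 4 nitrogen; one five-membered aromatic ring with 2 hetero atoms, one six-membered aromatic ring with 2 hetero atoms) in place of a group of 9 heavy atoms (7 carbon, 1 oxygen, 1 fluorine; one six-membered aromatic ring of carbon only), on an amine nitrogen. Among the compounds with values here, no measured step matches this change. Compound 3 is the nearer analogue in kind, since it too carries a bicyclic aromatic group directly on the amine nitrogen, and compound 3 gives 4810 nM where compound 2 gives 1810 nM. On that basis compound 4 is expected to give a higher number than compound 2, a step of about a 2.5-fold higher number from compound 2 to compound 4 (0.40 log units; beyond the scatter). The estimate for compound 4 in this assay is 4500 nM, with a range from 1500 nM to 13000 nM.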

Compound 4, half-maximal inhibitory concentration: 960 nM
Beside the measured number, compound 4's estimate is 4.7-fold (0.67 log units) above it; the whole stated range lies above it.
By their numbers in this assay, from the lowest: compounds 4, 2, 1 and 3 (each within the scatter of the next, the first and the last beyond it).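

The step of a 1.9-fold lower number from compound 2 to compound 4 (0.28 log units; within the scatter) in this assay shows that the group on the amine nitrogen can lose both its carbonyl and its carbon-only ring, taking a nitrogen-rich pair of aromatic rings with a hydrogen-bond donor instead, without the number moving beyond the scatter. It also shows that carrying two aromatic rings directly on the amine nitrogen does not by itself fix the number: compound 3 gives 4810 nM and compound 4 gives 960 nM, two values beyond the scatter of each other. Nothing measured here explains this difference between the two groups.

On these data alone, the carbonyl and the ring change together from compound 2 to compound 4, so the share of each stays open. As far as these compounds go, how a plain phenyl group or a small alkyl group directly on the amine nitrogen would compare also remains unknown.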